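Amide side-chain variation on the shared core

The compounds below may be only part of what the source reports. "The series", "measured", "known", "first", "only" and "open" are said of these compounds alone.

Values so far in an assay on CHO cells for displacement of a labelled ligand from adenosine receptor A1 (Homo sapiens), read by scintillation counting, with a stated time of 60 min, tested at 10 uM; a higher number here means more inhibition at the concentration tested (going by the name of the read-out), a lower number less inhibition:
compound 1 `COc1cccc2cc(C(=O)N[C@@H](CO)C(=O)O)c(=O)oc12` gives 12%
compound 2 `COCCNC(=O)c1cc2cccc(OC)c2oc1=O` gives 45%
compound 3 `O=C(NCCCN1CCN(CCCNC(=O)c2cc3ccccc3oc2=O)CC1)c1cc2ccccc2oc1=O` gives 9%

Compound 2 stands highest of the three numbers, and both gaps to it are beyond the scatter. Within the data shown here, its nearest neighbour is compound 1; the only single-point step in the set is a number 33 percentage points higher from compound 1 to compound 2 (beyond the scatter), which swapped away a side chain carrying both a carboxy and a hydroxy. Compound 3, which lacks the methoxy, is not a single-point partner of any other compound; its value is simply the lowest shown.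

Compound 4 `COc1cccc2cc(C(=O)NCCO)c(=O)oc12` is the next entry. Against compound 2 the change is hydrogen in place of methyl on an oxygen on a saturated carbon. Among the measured compounds shown here, the one step that bears on this is the step from compound 1 to compound 2, which was large; compound 4 reinstates a hydroxy on the side chain while keeping the carboxy out, so only part of that change is reversed. In this assay a drop for compound 4 is therefore expected, probably beyond the scatter but well short of the full size of the earlier step; the expected step is a number 15 percentage points lower from compound 2 to compound 4 (beyond the scatter). The estimate for compound 4 is 30%, with a range from 12% to 50%.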

Compound 4, a percentage reported as inhibition, at one concentration (the size of the read-out at that concentration, not a potency): 12%
For compound 4 the middle estimate is 18 percentage points above the measured one; low and high end bracket the measured number.
By their numbers in this assay, from the lowest: compounds 3, 1 and 4 (each within the scatter of the next); then compound 2.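

In this assay, replacing methyl with hydrogen on the side-chain oxygen, turning 2-methoxyethyl into 2-hydroxyethyl, gives a number 33 percentage points lower from compound 2 to compound 4 (beyond the scatter) and shows that this one methyl on the oxygen can separate a high reading from a low one in this pair. Hydrogen in place of carboxy on the saturated chain carbon gives no change at the digits printed from compound 1 to compound 4 (within the scatter) and so shows no readable effect of the carboxy in this assay, leaving the low reading of compound 1 matched by a side chain without that group. Among these side chains, the higher number therefore goes with the 2-methoxyethyl chain of compound 2, while the two chains carrying a free hydroxy stay together at the low end, and no measured evidence is available to explain this difference.

Going by these compounds, whether the higher reading survives an ethoxy in place of the methoxy, a longer chain carrying the same ether, or a 2-aminoethyl side chain stays open. Among these compounds, only one pair shows the methoxy to hydroxy change, so the size of that change on any other side chain is unknown.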